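Moving the hydroxymethyl group from compound 1 to compound 3

A few compounds are considered here, and "the series" means these few. Any claim that something is new, unique, unknown or untested is made for them only; others in the source may bear on it.

Compound 1 `O=S(=O)(Nc1cccc(CO)c1)c1ccc(-c2ccc(Br)cc2)cc1` gives 2500 nM
Compound 2 `O=S(=O)(Nc1cccc(CO)c1)c1ccc(-c2ccc(Cl)cc2)cc1` gives 2500 nM

In a functional assay on J774 cells (Mus musculus) for cytotoxicity, read by resazurin assay, with a stated time of 72 h (on this read-out lower numbers stand for stronger inhibition and higher numbers for weaker inhibition), compound 1 stands level with compound 2. Compound 3 `O=S(=O)(Nc1ccc(CO)cc1)c1ccc(-c2ccc(Br)cc2)cc1` has the same atoms as compound 1, joined differently: 4-(hydroxymethyl)phenyl in place of 3-(hydroxymethyl)phenyl on a sulfonamide nitrogen is the whole change. Among the measured compounds shown here, the one measured step of no change at the digits printed from compound 1 to compound 2 (within the scatter) is a different change, chloro in place of bromo on an aromatic carbon, and it stayed within the scatter. For the measured compounds named here, no measured pair tests the move of the hydroxymethyl group itself, so the evidence is thin. The expected size is no change at the digits printed from compound 1 to compound 3 (within the scatter) in this assay with no direction favoured, so no step beyond the scatter is expected. Compound 3 is estimated at 2500 nM with an expected range from 1000 nM to 6500 nM in this read-out.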

Compound 3, half-maximal inhibitory concentration: 3500 nM
The estimate for compound 3 lay 1.4-fold (0.15 log units) below the measured number, within the range that was stated.
By their numbers in this assay, from the lowest: compounds 1, 2 and 3 (each within the scatter of the next).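

With 4-(hydroxymethyl)phenyl in place of 3-(hydroxymethyl)phenyl on the sulfonamide nitrogen, the result is a 1.4-fold higher number from compound 1 to compound 3 (0.15 log units; within the scatter) in this assay for this cytotoxicity read-out. Among the compounds shown here, this is the first measured test of moving the hydroxymethyl group itself, and the move does not separate the two compounds here. Nothing shown gives a reason for this result.

Still open, on these data alone, is whether an amine or a carboxylic acid in place of the hydroxymethyl group would step beyond the scatter. Also open, as far as these compounds go, is whether the same move behaves alike with chloro in place of bromo.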